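Compound 3 to compound 4: exchange on the amide

The source may hold more compounds than are shown below. What is called first, only, known or untested is meant among the compounds shown, and "the series" means these compounds.

Measured in an in vitro ADME assay on microsomes from liver (Mus musculus) for pharmacokinetics, read by LC-MS, with a stated time of 10 min, tested at 1 uM; a lower number here means slower removal, a higher number faster removal of the compound:
- compound 1 `CN1C[C@H](C(=O)Nc2ccc(C3CC3)cc2)[C@@H](c2ccc(/C=C/C(=O)Nc3ccccc3N)cc2)C1`: 60 mL/min/kg
- compound 2 `CN1C[C@H](C(=O)Nc2cccc(F)c2)[C@@H](c2ccc(/C=C/C(=O)Nc3ccccc3N)cc2)C1`: 56 mL/min/kg
- compound 3 `Cc1cc(NC(=O)[C@H]2CN(C)C[C@@H]2c2ccc(/C=C/C(=O)Nc3ccccc3N)cc2)ccc1Cl`: 65 mL/min/kg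

In this assay the three compounds form a single level, and compound 3 at 65 mL/min/kg lies within the scatter of both others. The next structure is compound 4 `CN1C[C@H](C(=O)Nc2cccnc2)[C@@H](c2ccc(/C=C/C(=O)Nc3ccccc3N)cc2)C1`, which carries pyridin-3-yl in place of 4-chloro-3-methylphenyl on an amide-type nitrogen.

The measured steps that bear on this are the exchanges at the same place. They are a 1.1-fold lower number from compound 1 to compound 2 (0.03 log units; within the scatter), a 1.1-fold higher number from compound 1 to compound 3 (0.03 log units; within the scatter) and a 1.2-fold higher number from compound 2 to compound 3 (0.06 log units; within the scatter). All three stay within the scatter, although the groups exchanged differ clearly in structure. Within the data shown here, no measured compound carries pyridin-3-yl, or any ring with a hetero atom at this place, so the data give no direction for this exchange and their reach is limited.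

A step beyond the scatter is therefore not expected, and the estimate sits only slightly under the measured level. The expected step is a 1.3-fold lower number from compound 3 to compound 4 (0.10 log units; within the scatter). For compound 4 the estimated value is 52 mL/min/kg, with an expected range of 30 mL/min/kg to 80 mL/min/kg.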

Compound 4, clearance: 41 mL/min/kg
For compound 4 the middle estimate is 1.3-fold (0.10 log units) above the measured one, within the range that was stated.
By their numbers in this assay, from the lowest: compounds 4, 2, 1 and 3 (each within the scatter of the next).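

Pyridin-3-yl brings the first ring with a hetero atom to this place on the amide-type nitrogen, and in this assay the exchange gives a 1.6-fold lower number from compound 3 to compound 4 (0.20 log units; within the scatter) and a 1.4-fold lower number from compound 2 to compound 4 (0.14 log units; within the scatter) and a 1.5-fold lower number from compound 1 to compound 4 (0.17 log units; within the scatter) for the three rings of carbon only. All four compounds therefore remain on one level, so neither the hydrogen-bond acceptor of pyridin-3-yl, which compound 1, compound 2 and compound 3 lack at this place, nor the loss of the chlorine and methyl of compound 3 carries the clearance beyond the scatter. No measurement accompanies these numbers that could tie them to any property of the groups.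

On these data alone, whether pyridin-2-yl, pyridin-4-yl, a saturated ring such as piperidin-4-yl, or a phenyl ring carrying an amine or a carboxylic acid would stay on this level remains open. As far as these compounds go, all four compounds share the rest of the structure, so it is also open whether an exchange outside this place would move the clearance further than any exchange on the amide-type nitrogen has done here.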